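A few compounds are considered here, and "the series" means these few. Any claim that something is new, unique, unknown or untested is made for them only; others in the source may bear on it.

Working notes on the series. Two compounds carry numbers in a physicochemical assay for lipophilicity; a higher number here means a more lipophilic compound, a lower number a more polar compound. Compound 1, `CCCN(CCn1cc[n+](C)c1/C=N/O)S(=O)(=O)C(F)(F)F`, gives in this assay a distribution coefficient of -0.69. Compound 2, `CCN(CCn1cc[n+](C)c1/C=N/O)S(=O)(=O)c1ccccc1`, gives in this assay a distribution coefficient of -1.39. Of the two, compound 2 stands lower; the number for compound 1 lies higher by a margin beyond the usual scatter of repeated measurements. Among the compounds with values here, the two compounds differ in more than one place, so no single structural step links them, and the gap is left as it stands.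

Compound 3, `CCCN(CCn1cc[n+](C)c1/C=N/O)S(=O)(=O)c1ccccc1`, is the next member without a number. Against compound 2 the change is methyl in place of hydrogen on a saturated chain carbon, two bonds along the chain from a sulfonamide nitrogen. A saturated carbon added to a chain of this kind, with no donor, no acceptor and no charge, is the sort of change that usually moves the distribution coefficient upward, by a modest amount at most. The step of a number 0.39 log units higher from compound 2 to compound 3 (beyond the scatter) is therefore expected upward, small but likely beyond the scatter. Compound 3 is accordingly estimated at -1 in this assay. For compound 3 the range of the expectation runs from -1.4 to -0.6.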

Compound 3, distribution coefficient: -0.94
The estimate for compound 3 lay 0.06 log units below the measured number; measured number inside the range.
By their numbers in this assay, from the lowest: compound 2; then compounds 3 and 1 (each within the scatter of the next).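

Methyl in place of hydrogen on a saturated chain carbon, two bonds along the chain from a sulfonamide nitrogen, gives the first single-place reading at this position in this assay: a number 0.45 log units higher from compound 2 to compound 3 (beyond the scatter), with the same difference reading as ethyl to propyl when cut one bond further out. Within the data shown here, compound 3 also supplies the first single-place reading at the sulfonyl sulfur, where phenyl in place of trifluoromethyl gives a number 0.25 log units lower from compound 1 to compound 3 (within the scatter), so with propyl in the molecule the gap first seen between compound 1 and compound 2 is resolved into one step beyond the scatter and one within it. Nothing measured on these compounds speaks to the origin of either step.

Open, going by these compounds, is whether butyl or a longer chain at this position would extend the step seen with propyl, and whether an amine or a carboxylic acid on the same chain would send the number the other way. Also open, on these data alone, is whether phenyl and trifluoromethyl on the sulfonyl sulfur remain within the scatter of each other with ethyl in place of propyl, and where a pyridine ring or a plain methyl on that sulfur would stand.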